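Swapping the Sulfonyl Aryl Group in a Quinoline Series

The source may hold more compounds than are shown below. What is called first, only, known or untested is meant among the compounds shown, and "the series" means these compounds.

Measured compounds:
compound 1, `CC1CCN(c2c(S(=O)(=O)c3ccc(C#N)cc3)cnc3cc(F)ccc23)CC1`, 83%
compound 2, `NC(=O)C1CCN(c2c(S(=O)(=O)c3ccccc3)cnc3ccccc23)CC1`, 24.8%

Both were tested in an assay on isolated protein for displacement of a labelled ligand from metabotropic glutamate receptor 5 (Homo sapiens), with a stated time of 60 min, tested at 1 uM; on this read-out higher numbers stand for more inhibition at the one concentration tested (going by the name of the read-out) and lower numbers for less inhibition. Compound 1 gives the higher of the two numbers shown, and its nearest neighbour, compound 2, lies a long way below it, a gap reported as beyond the usual scatter; since the two structures differ in several places at once, no single step can be drawn between them.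

Among the compounds with values here, the unmeasured compound 3, `CC1CCN(c2c(S(=O)(=O)c3ccc(F)c(Cl)c3)cnc3cc(F)ccc23)CC1`, keeps the core of compound 1 and changes only one group: 3-chloro-4-fluorophenyl in place of 4-cyanophenyl on a sulfonyl sulfur.

Within the data shown here, no measured pair isolates this change, so the expectation rests on compound 1 alone, with 83% as the starting point. A step of modest size downward, or none beyond the scatter, is expected in this assay, giving an estimated a number 13 percentage points lower from compound 1 to compound 3 (beyond the scatter). Compound 3 is therefore expected to show 70%, within a range from 45% to 90%.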

Compound 3, a percentage reported as inhibition, at one concentration (the size of the read-out at that concentration, not a potency): 94%
Beside the measured number, compound 3's estimate is 24 percentage points below it; the whole stated range lies below it.
By their numbers in this assay, from the lowest: compound 2; then compound 1; then compound 3.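

In this assay, the group on a sulfonyl sulfur proves open to exchange: 3-chloro-4-fluorophenyl in place of 4-cyanophenyl gives a number 11 percentage points higher from compound 1 to compound 3 (beyond the scatter). Within the data shown here, the nitrile is therefore not required for a high number on the core of compound 1, and the pair gives the first reading of this position with everything else held constant. No available data offer an explanation for this step.

The compounds shown leave open whether the chlorine, the fluorine or the two together account for the step, since both enter at once, and whether a methoxy group or a pyridine ring on a sulfonyl sulfur would do as well. They also leave open whether the same change would carry over to a different group at the other varied sites, such as the carboxamide of compound 2.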